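Tetrazolyl versus triazolyl thioether in a cytotoxicity series

This account rests on a few compounds, and the source may have more. Where it says the series, first, only, none or still open, it means among the compounds named here.

Measured so far:
compound 1 `O=C(CSc1nnnn1-c1ccccc1)N/N=c1/scc(-c2ccc([N+](=O)[O-])cc2)n1-c1ccccc1`: 14.3 ug/mL
compound 2 `Cn1cnnc1SCC(=O)N/N=c1/scc(-c2ccccc2)n1-c1ccccc1`: 217 ug/mL

In an ADME assay on NIH3T3 cells (Mus musculus) for cytotoxicity, read by MTT assay, with a stated time of 24 h (on this read-out higher numbers stand for weaker inhibition and lower numbers for stronger inhibition), compound 2 gives the highest number of the two; compound 1 lies well below it, and the gap is beyond the scatter. Among the compounds with values here, compound 1 and compound 2 differ in more than one place, so no single-change step links them.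

Compound 3 `O=C(CSc1nnnn1-c1ccccc1)N/N=c1/scc(-c2ccccc2)n1-c1ccccc1` is not yet measured. It differs from compound 2 in one place: 1-phenyl-1H-tetrazol-5-yl in place of 4-methyl-4H-1,2,4-triazol-3-yl on a sulfur. Within the data shown here, the entering group is the one that compound 1 also carries, though compound 1 differs from compound 3 elsewhere as well, so its value is only a loose pointer.

A step downward from compound 2 is expected, of a size a 4.3-fold lower number from compound 2 to compound 3 (0.64 log units; beyond the scatter), since compound 1 with the same tetrazolyl group gives 14.3 ug/mL. For compound 3 the estimated value in this assay is 50 ug/mL, with a range from 12 ug/mL to 200 ug/mL.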

Compound 3, half-maximal inhibitory concentration: 417 ug/mL
Compound 3: the middle estimate sits 8.3-fold (0.92 log units) below what was measured, outside the stated range (above it).
By their numbers in this assay, from the lowest: compound 1; then compounds 2 and 3 (each within the scatter of the next).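

In this assay, 1-phenyl-1H-tetrazol-5-yl in place of 4-methyl-4H-1,2,4-triazol-3-yl on a sulfur gives a 1.9-fold higher number from compound 2 to compound 3 (0.28 log units; within the scatter) and so leaves the read-out unresolved between these two groups at this place. The low number of compound 1 therefore does not travel with the tetrazolyl group: hydrogen in place of nitro on an aromatic carbon gives a 29-fold higher number from compound 1 to compound 3 (1.46 log units; beyond the scatter) as a single change, and the large step lies at that place. Nothing at hand bears on the reason for either step.

Going by these compounds, whether the nitro step holds with 4-methyl-4H-1,2,4-triazol-3-yl on the sulfur stays open, as does whether an amine or a chlorine in place of nitro moves the number in the same way. Also open, on these data alone, is whether a plain methyl on the sulfur would stay level with these two ring groups.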